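Ethoxycarbonyl Ester Added to the Aryl Ring of Compound 3

The source may report more compounds than this note shows. Statements on the series, on what has been measured and on what is new or still open speak of the compounds shown alone.

Compound 1 `NS(=O)(=O)NCC1CCN(c2cc(-c3ccccc3)ncn2)CC1`: 34300 nM
Compound 2 `COC(=O)c1ccc(-c2cc(N3CCC(CNS(N)(=O)=O)CC3)ncn2)cc1`: 17700 nM
Compound 3 `NS(=O)(=O)NCCC1CCN(c2cc(-c3ccccc3)ncn2)CC1`: 53200 nM

Of the compounds shown here, three sharing one core have been measured in a functional assay on MCF7 cells (Homo sapiens) for antiproliferative activity, read by sulforhodamine B assay, with a stated time of 48 h; a higher number here means a weaker inhibitor of growth, a lower number a stronger inhibitor of growth. Compound 3 sits at the highest of the three numbers. Its nearest neighbour is compound 1, the difference being a 1.6-fold higher number from compound 1 to compound 3 (0.19 log units; within the scatter). Compound 2 gives 17700 nM in this assay, and the gap from compound 3 to that value lies beyond the usual scatter.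

Compound 4 `CCOC(=O)c1ccc(-c2cc(N3CCC(CCNS(N)(=O)=O)CC3)ncn2)cc1` has not yet been measured. It differs from compound 3 in one place: ethoxycarbonyl in place of hydrogen on an aromatic carbon. Among the measured compounds shown here, the measured step that bears on this change is the one from compound 1 to compound 2, where a methoxycarbonyl group replaced hydrogen on the same aromatic carbon, giving a 1.9-fold lower number from compound 1 to compound 2 (0.29 log units; within the scatter). Since that step stayed within the scatter, the closely related ethoxycarbonyl group is expected to produce at most a modest shift in this assay, most likely toward a lower number, with no change beyond the scatter being equally plausible.

Compound 4 is therefore estimated at 31000 nM, with a range from 12000 nM to 80000 nM. This estimate corresponds to an expected 1.7-fold lower number from compound 3 to compound 4 (0.23 log units; within the scatter).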

Compound 4, concentration for 50% growth inhibition: 6200 nM
Compound 4: the middle estimate sits 5.0-fold (0.70 log units) above what was measured, and the stated range ends above it.
By their numbers in this assay, from the lowest: compound 4; then compounds 2, 1 and 3 (each within the scatter of the next, the first and the last beyond it).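

In this assay, ethoxycarbonyl in place of hydrogen on the aromatic carbon para to a large group gives an 8.6-fold lower number from compound 3 to compound 4 (0.93 log units; beyond the scatter) and so shows that a change at this position can move the number beyond the scatter, which the methoxycarbonyl step (a 1.9-fold lower number from compound 1 to compound 2 (0.29 log units; within the scatter)) did not show. The two steps differ both in the ester and in the chain that carries the sulfamoylamino group, so the compounds shown cannot tell which of these differences goes with the larger step. Nothing measured here bears on why this step is the larger one.

The compounds shown leave open how a carboxylic acid or a primary amide on the same aromatic carbon would read in this assay, and whether the activity follows the ester as such or depends on its ethyl part. They also leave open what ethoxycarbonyl would do on the shorter chain of compound 1, and whether a still longer chain on the saturated ring would carry the same step.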